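Swapping a Pyridinyl for a Fluoromethoxyphenyl: Cytotoxicity Outlook

The compounds below may be only part of what the source reports. "The series", "measured", "known", "first", "only" and "open" are said of these compounds alone.

Three compounds have been run in an ADME assay on BJ cells (Homo sapiens) for cytotoxicity, read by CellTiter-Glo and resazurin assay, with a stated time of 72 h; a lower number here means that less compound is needed, a higher number that more compound is needed for the effect. Compound 1 `CC(C)N(Cc1cccc(OCCCCCC(=O)O)c1)C(=O)c1ccc(-c2cccc(-c3ccccc3)c2)cc1` gives > 26000 nM, which is a limit of the assay rather than a number. Compound 2 `COc1cccc(-c2ccc(C(=O)N(Cc3cccc(OCCCCCC(=O)O)c3)C(C)C)cc2)c1` gives > 20900 nM, again only a limit. The step that the two limits leave unreadable from compound 1 to compound 2 therefore cannot be read. Compound 3 `CCOC(=O)CCCCCOc1cccc(CN(C(=O)c2ccc(-c3cccnc3)cc2)C(C)C)c1` gives > 26000 nM, once more a limit. All three values sit at the edge of what the assay reports: two of them at the limit of > 26000 nM in this assay, at which 2 of the 3 values shown sit, and one at the limit of > 20900 nM in this assay, at which 1 of the 3 values shown sits. Compound 4 `CCOC(=O)CCCCCOc1cccc(CN(C(=O)c2ccc(-c3cc(F)cc(OC)c3)cc2)C(C)C)c1` differs from compound 3 by 3-fluoro-5-methoxyphenyl in place of pyridin-3-yl on an aromatic carbon. Within the data shown here, no measured step is readable, so nothing points to a change beyond the scatter. Compound 4 is therefore expected to return a limit again, an estimate of 26000 nM with a range from 18000 nM to 40000 nM, the implied step a number no higher from compound 3 to compound 4 (the limit leaves the size open) being too small to see.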

Compound 4, half-maximal effective concentration: > 26000 nM
Compound 4 gave a limit, no number; the forecaster's own chance of this, stated with the estimate: 85%; the middle value lies on the limit itself.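

Compound 3 and compound 4 both return only limits of the assay, so the step between them cannot be read. The compounds shown leave open what concentration, if any, would reach the half-maximal effect in this assay.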